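This account rests on a few compounds, and the source may have more. Where it says the series, first, only, none or still open, it means among the compounds named here.

Compound 2 `CC(C)N1CCN(CCCN(C[C@H]2Cc3ccccc3CN2)[C@H]2CCCc3cccnc32)CC1` stands highest of the two numbers in an ADME assay on microsomes from liver (Mus musculus) for metabolic stability, read by LC-MS, with a stated time of 10 min, tested at 0.5 uM (on this read-out higher numbers stand for a more stable compound and lower numbers for a less stable compound), where compound 2 gives 58%; compound 1 `c1ccc2c(c1)CN[C@@H](CN(CC1CCNCC1)[C@H]1CCCc3cccnc31)C2` gives 13%. Going by the values given here, the one measured step, a number 45 percentage points higher from compound 1 to compound 2 (beyond the scatter), bears on the change to compound 3 `c1ccc2c(c1)CN[C@@H](CN(CCN1CCNCC1)[C@H]1CCCc3cccnc31)C2`: piperazin-1-yl in place of (4-isopropylpiperazin-1-yl)methyl on a saturated chain carbon, two bonds along the chain from an amine nitrogen. Since the (4-isopropylpiperazin-1-yl)methyl group that accompanied that large gain leaves and piperazin-1-yl enters in its place, a step back downward, beyond the scatter, is expected, a number 33 percentage points lower from compound 2 to compound 3 (beyond the scatter). Compound 3 is estimated at 25% in this assay, with a range from 10% to 50%.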

Compound 3, percent of the compound remaining: 79%
Estimate against measurement, compound 3: 54 percentage points below, outside the stated range (above it).
By their numbers in this assay, from the lowest: compound 1; then compound 2; then compound 3.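

In this assay the step does not fall back: piperazin-1-yl in place of (4-isopropylpiperazin-1-yl)methyl gives a number 21 percentage points higher from compound 2 to compound 3 (beyond the scatter) and so adds to the earlier gain. Measured against piperidin-4-yl, (piperazin-1-yl)methyl gives a number 66 percentage points higher from compound 1 to compound 3 (beyond the scatter) as the largest step shown, so the isopropyl group is not required for a high number at this place. No measurement in hand accounts for either rise.

This change removes the isopropyl group and shortens the chain together, leaving their separate contributions unresolved. Also open, from the compounds shown here alone, is whether a morpholin-4-yl group or a longer chain would hold the number.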